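Removing a Chloro Group and Tolerated Concentration

A few compounds are considered here, and "the series" means these few. Any claim that something is new, unique, unknown or untested is made for them only; others in the source may bear on it.

Three amides have been tested for how much of them cultured cells tolerate. Compound 1 `O=C(Nc1ccccc1)c1cc(Br)cc(Br)c1` carries no substituent on the ring that holds the amide nitrogen. In an ADME assay on HEK293 cells (Homo sapiens) for cytotoxicity, read by reporter gene assay and resazurin assay, with a stated time of 48 h (a lower number here means that less compound is tolerated, a higher number that more compound is tolerated), compound 1 reaches only a limit of the assay, > 100000 nM, and no number. Compound 2 `O=C(Nc1cccc(Cl)c1)c1cc(Br)cc(Br)c1` differs from compound 1 in one place: hydrogen in place of chloro on an aromatic carbon. In this assay compound 2 gives 53000 nM. The step of an at least 1.8-fold higher number from compound 2 to compound 1 (0.27 log units; that floor lies within the scatter) is known only as a floor because compound 1 sits at the limit of > 100000 nM in this assay, at which 1 of the 3 values shown sits.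

Compound 3 `O=C(Nc1cccc(Cl)c1)c1cccc(Br)c1O` is built on another core; the difference between the two cores is not broken down here. In this assay compound 3 gives 32000 nM, and that number and the number of compound 2 lie within the usual scatter of each other.

Compound 4 `O=C(Nc1ccccc1)c1cccc(Br)c1O` is not yet measured. It stands to compound 3 as compound 1 stands to compound 2: hydrogen in place of chloro on an aromatic carbon. The place of the change is described in the same words for both pairs, so this is the same change made on the other core. In this assay compound 4 is expected to move by a 1.9-fold higher number from compound 3 to compound 4 (0.27 log units; within the scatter), since the same change produced an at least 1.8-fold higher number from compound 2 to compound 1 (0.27 log units; that floor lies within the scatter) and that earlier step is only a floor. In this assay compound 4 is estimated at 60000 nM, with a range from 30000 nM to 120000 nM.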

Compound 4, half-maximal cytotoxic concentration: 82000 nM
Compound 4: the middle estimate sits 1.4-fold (0.14 log units) below what was measured, and the stated range covers the measured number.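

In this assay the swap of hydrogen for chloro on the second core gives a 2.6-fold higher number from compound 3 to compound 4 (0.41 log units; beyond the scatter), so here cells tolerate more of the compound without the chloro group, by a margin larger than the usual scatter. On both cores the change goes with a higher number, but the first step is known only as a floor, and the sizes of the two steps cannot be compared: the same change on two cores in this assay, an at least 1.8-fold higher number (0.27 log units; that floor lies within the scatter) from compound 2 to compound 1 and a 2.6-fold higher number (0.41 log units; beyond the scatter) from compound 3 to compound 4; the limit leaves it open whether they differ. Two pairs on two cores show that the change carried over in direction here, but they give no general rule for other cores, and one value in this set is a limit of the assay and not a number: the limit of > 100000 nM in this assay, at which 1 of the 4 values shown sits.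

The compounds shown leave open how much of the difference between the two cores comes from the hydroxyl group and how much from the bromo groups, since no pair here separates them. They also leave open whether the higher number goes with the loss of chloro alone or would also appear if another group, such as a methoxy group or an amine, took the place of the chloro group.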